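The source may hold more compounds than are shown below. What is called first, only, known or untested is meant among the compounds shown, and "the series" means these compounds.

Of the compounds shown here, two have been measured in an assay (Rattus norvegicus) for inhibition of Fatty-acid amide hydrolase 1 (Homo sapiens); a lower number here means a stronger inhibitor, a higher number a weaker inhibitor. Compound 1 `N#Cc1ccccc1-c1cnc(C(=O)CCCCCCc2ccccc2)o1` gives 130 nM, while compound 2 `NC(=O)c1ccc(-c2cnc(C(=O)CCCCCCc3ccccc3)o2)nc1` gives 1.2 nM. Among the measured compounds shown here, the single step between them, a 110-fold lower number from compound 1 to compound 2 (2.03 log units; beyond the scatter), swaps 2-cyanophenyl for 5-carbamoylpyridin-2-yl and is the only change recorded so far. For the measured compounds named here, on these numbers compound 2 stands lowest of the two, with compound 1 as its only neighbour, and that gap lies well beyond the scatter.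

Compound 3 `NC(=O)c1cccc(-c2cnc(C(=O)CCCCCCc3ccccc3)o2)n1` has not been measured. It differs from compound 2 by 6-carbamoylpyridin-2-yl in place of 5-carbamoylpyridin-2-yl on an aromatic carbon; the two have the same atoms, joined differently, so the carbamoyl group simply sits elsewhere on the same ring. Going by the values given here, no measured step bears directly on such a rearrangement: the one step recorded replaces the whole aromatic group at once and cannot be split into ring and substituent parts. Without an anchor, a small to moderate change is expected, more likely a rise than a further fall, as compound 2 already gives 1.2 nM, the lowest here. Compound 3 is therefore estimated at 3 nM, within 0.8 nM to 15 nM, an expected step of a 2.5-fold higher number from compound 2 to compound 3 (0.40 log units; beyond the scatter).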

Compound 3, inhibition constant: 1 nM
Estimate against measurement, compound 3: 3.0-fold (0.48 log units) above; low and high end bracket the measured number.
By their numbers in this assay, from the lowest: compounds 3 and 2 (each within the scatter of the next); then compound 1.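

In this assay, the carbamoyl group can stand in either of two places on the pyridine ring without a readable difference: the step is a 1.2-fold lower number from compound 2 to compound 3 (0.08 log units; within the scatter), so compound 2 and compound 3 cannot be told apart. The pyridine ring sits in the same place in both, on the aromatic carbon next to the ring oxygen, so this position accepts both 5-carbamoylpyridin-2-yl and 6-carbamoylpyridin-2-yl. The large difference from the 2-cyanophenyl group also appears a second time, as a 130-fold lower number from compound 1 to compound 3 (2.11 log units; beyond the scatter), which shows that it does not depend on just one placement of the carbamoyl group, though nothing available explains why the two placements read alike.

The compounds shown still do not separate the part played by the ring nitrogen from that of the carbamoyl group, as 2-cyanophenyl differs from both pyridine groups in ring and substituent at once. A phenyl ring carrying the carbamoyl group would address the ring nitrogen, and a carboxylic acid or an amine in the carbamoyl group's place would test how much that group itself matters.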